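The compounds below may be only part of what the source reports. "The series", "measured", "known", "first", "only" and "open" are said of these compounds alone.

Measured in a functional assay on M21 cells (Homo sapiens) for antiproliferative activity, read by sulforhodamine B assay, with a stated time of 48 h; a higher number here means a weaker inhibitor, a lower number a stronger inhibitor:
compound 1 `Cc1cccc(OS(=O)(=O)c2ccc(N3CCN(C)C3=O)cc2)c1`: 2300 nM
compound 2 `COc1cccc(OS(=O)(=O)c2ccc(N3CCN(C)C3=O)cc2)c1`: 1600 nM
compound 3 `CCCN1CCN(c2ccc(S(=O)(=O)Oc3ccc(C)cc3)cc2)C1=O`: 28000 nM

Compound 1 and compound 2 share a core and differ by methoxy in place of methyl on an aromatic carbon; that change made a 1.4-fold lower number from compound 1 to compound 2 (0.16 log units; within the scatter). Compound 3 stands on a different core, and the difference between the two cores is not broken down here; its value is the highest of the three. Compound 4 `CCCN1CCN(c2ccc(S(=O)(=O)Oc3ccc(OC)cc3)cc2)C1=O` is the unmeasured partner of compound 3, carrying (methoxy in place of methyl on an aromatic carbon). For the measured compounds named here, this is the same kind of change as the one from compound 1 to compound 2, but the place is not identical: here the group sits para to a large group, there meta to a large group. Because the earlier step was a 1.4-fold lower number from compound 1 to compound 2 (0.16 log units; within the scatter), a step of similar size is expected, namely a 1.4-fold lower number from compound 3 to compound 4 (0.15 log units; within the scatter). Compound 4 is therefore estimated at 20000 nM in this assay, with an expected range from 7000 nM to 60000 nM.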

Compound 4, half-maximal inhibitory concentration: 23000 nM
Compound 4: middle estimate off by 1.2-fold (0.06 log units), on the low side, within the range that was stated.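

In this assay, methoxy in place of methyl on an aromatic carbon gave a 1.2-fold lower number from compound 3 to compound 4 (0.09 log units; within the scatter), so the step on the core of compound 3 is small, as it was on the core of compound 1. Set side by side, the two steps do not differ beyond the scatter: the same change on two cores in this assay, a 1.4-fold lower number (0.16 log units; within the scatter) from compound 1 to compound 2 and a 1.2-fold lower number (0.09 log units; within the scatter) from compound 3 to compound 4, 1.2-fold (0.07 log units) apart, within the scatter of two such steps. This shows that the change carried across both cores with no visible shift in the number, but neither step lies beyond the scatter, the place on the ring is not the same in the two pairs, and two pairs set no rule for the series.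

The compounds shown leave open whether an amine, a carboxylic acid or a longer chain in that place would move the number beyond the scatter. They also leave open whether either core would respond alike to such a group.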